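A few compounds are considered here, and "the series" means these few. Any claim that something is new, unique, unknown or untested is made for them only; others in the source may bear on it.

Measured so far:
compound 1 `CN1CCC(n2cc(S(=O)(=O)c3cccc(F)c3)c3ccccc32)C1`: 49%
compound 2 `O=S(=O)(c1cccc(F)c1)c1cn(C2CCNC2)c2ccccc12`: 38%

Among the compounds with values here, in a functional assay on HeLa cells for agonist activity at 5-hydroxytryptamine receptor 6 (Homo sapiens), read by cAMP accumulation and immunoassay, with a stated time of 10 min (a higher number here means a larger maximal response, a lower number a smaller maximal response), compound 2 stands lowest of the two numbers; the step of a number 11 percentage points lower from compound 1 to compound 2 (beyond the scatter) is the only measured step, and it concerns hydrogen in place of methyl on an amine nitrogen in a ring, not the size of that ring. Compound 3 `O=S(=O)(c1cccc(F)c1)c1cn(C2CCCNC2)c2ccccc12` differs from compound 2 by piperidin-3-yl in place of pyrrolidin-3-yl on an aromatic nitrogen. Within the data shown here, no measured step bears on enlarging the ring that carries the amine, so the expectation rests on compound 2 alone, with no step beyond the scatter expected. The expected value for compound 3 is 40%, range 20% to 62%, meaning an expected a number 2 percentage points higher from compound 2 to compound 3 (within the scatter).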

Compound 3, largest response reached (Emax), in percent of the reference or control that the assay uses: 78%
Compound 3: middle estimate off by 38 percentage points, on the low side; the whole stated range lies below it.
By their numbers in this assay, from the lowest: compound 2; then compound 1; then compound 3.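

In this assay, the size of the ring on the aromatic nitrogen matters far more than the earlier methyl change suggested: piperidin-3-yl in place of pyrrolidin-3-yl gives a number 40 percentage points higher from compound 2 to compound 3 (beyond the scatter) and is a large step. Piperidin-3-yl also outperforms the 1-methylpyrrolidin-3-yl group, with a number 29 percentage points higher from compound 1 to compound 3 (beyond the scatter), leaving compound 3 highest of the three. Nothing available accounts for this gain.

Still open, going by these compounds, is whether 1-methylpiperidin-3-yl would hold or lower the response of compound 3. On these data alone, the effects of piperidin-4-yl and azepan-3-yl at this position also remain unknown.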